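The source may hold more compounds than are shown below. What is called first, only, known or untested is meant among the compounds shown, and "the series" means these compounds.

Working notes on the series.

Compound 1 `COc1ccc2c(OCC[C@@H]3NC(=O)N(C)CCCC/C=C\[C@@H]4C[C@@]4(C(=O)NS(=O)(=O)C4(C#N)CC4)NC3=O)cc(-c3nc(C(C)C)cs3)nc2c1Cl` is the anchor for this step. In an ADME assay on cells (Homo sapiens) for activation (a lower number here means that less compound is tolerated, a higher number that more compound is tolerated), compound 1 shows only a limit, recorded as > 75000 nM. That reading sits at the limit of > 75000 nM in this assay, at which 1 of the 3 values shown sits, so no number is known for compound 1 and only a floor can be stated. Two further members of the series give numbers in this assay: compound 2 `COc1ccc2c(OCC[C@@H]3NC(=O)N(C)CCCC/C=C\[C@@H]4C[C@@]4(C(=O)NS(=O)(=O)C4(C)CC4)NC3=O)cc(-n3ccc(C(C)C)n3)nc2c1Cl` gives 31000 nM, and compound 3 `CCn1cc(-c2cc(OCC[C@@H]3NC(=O)N(C)CCCC/C=C\[C@@H]4C[C@@]4(C(=O)NS(=O)(=O)C4(C)CC4)NC3=O)c3ccc(OC)c(C)c3n2)cn1` gives 36700 nM. Compound 2 and compound 3 differ from compound 1 in more than one place, so no single step can be read off from them; what they show is that the series as a whole is tolerated at high concentration in this assay.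

The unmeasured compound 4 `COc1ccc2c(OCC[C@@H]3NC(=O)N(C)CCCC/C=C\[C@@H]4C[C@@]4(C(=O)NS(=O)(=O)N4CCC[C@H]4C#N)NC3=O)cc(-c3nc(C(C)C)cs3)nc2c1Cl` differs from compound 1 in one place on the sulfonyl sulfur (2-cyanopyrrolidin-1-yl in place of 1-cyanocyclopropyl on a sulfonyl sulfur). Within the data shown here, there is no measured step to calibrate such a change in this assay. The working expectation is a step from compound 1 to compound 4 of an at least 1.0-fold lower number from compound 1 to compound 4 (0.02 log units; that floor lies within the scatter), that is, none beyond the usual scatter, with the measurement for compound 4 likely to come back again as a limit. On that basis compound 4 is estimated at 70000 nM in this assay, with a range of 30000 nM to 150000 nM.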

Compound 4, half-maximal cytotoxic concentration: 28300 nM
The estimate for compound 4 lay 2.5-fold (0.39 log units) above the measured number; the measured number lies below the stated range.
By their numbers in this assay, from the lowest: compounds 4, 2 and 3 (each within the scatter of the next). At a limit, above all of these: compound 1.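

The sulfonyl sulfur is not a silent position in this assay: 2-cyanopyrrolidin-1-yl in place of 1-cyanocyclopropyl gives an at least 2.6-fold lower number from compound 1 to compound 4 (0.42 log units; beyond the scatter), the only single-place step shown in the series and one that lies beyond the scatter. Both groups carry one triple bond and no hydrogen-bond donors, so the change lies in the five-membered ring with its hetero atom replacing the three-membered carbon ring, and in the defined stereocentre, and the data cannot divide the step among these features. The true size of the step remains open, and only its minimum is known, since compound 1 stands at a limit: the limit of > 75000 nM in this assay, at which 1 of the 4 values shown sits.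

From the compounds shown here alone, it remains open whether a pyrrolidin-1-yl group without the nitrile, or a six-membered piperidin-1-yl group, on the same sulfonyl sulfur would give a number close to that of compound 4, and whether the opposite configuration at the stereocentre of the 2-cyanopyrrolidin-1-yl group matters. Going by these compounds, it is equally open whether the same exchange would give a step of similar size on a compound carrying a different group on the shared core.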